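A carbamoyl exchange on a compound at the assay limit

The compounds below may be only part of what the source reports. "The series", "measured", "known", "first", "only" and "open" are said of these compounds alone.

In an ADME assay on cells (Erythrocyte, Homo sapiens), read by spectrophotometry and hemolysis, with a stated time of 24 h (a lower number here means a stronger inhibitor, a higher number a weaker inhibitor), compound 1 `CC1(C)[N+]([O-])=c2ccc(COc3ccc(C=O)cc3)cc2=[N+]1[O-]` gives 65 uM, and compound 2 `NC(=S)N/N=C\c1ccccc1OCc1ccc2no[n+]([O-])c2c1` gives 189 uM. Compound 3 `CC1(C)[N+]([O-])=c2ccc(COc3ccccc3/C=N\NC(N)=S)cc2=[N+]1[O-]` returns no number, only a limit of the assay: > 200 uM. Compound 3 therefore stands at the limit of > 200 uM in this assay, at which 1 of the 3 values shown sits.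

Compound 4 `CC1(C)[N+]([O-])=c2ccc(COc3ccccc3/C=N\NC(N)=O)cc2=[N+]1[O-]` differs from compound 3 in one place: a group of 3 heavy atoms (1 carbon, 1 nitrogen, 1 oxygen; no ring) in place of a group of 3 heavy atoms (1 carbon, 1 nitrogen, 1 sulfur; no ring), on an amine nitrogen. A carbamoyl group takes the place of a group of 3 heavy atoms (1 carbon, 1 nitrogen, 1 sulfur; no ring), on an amine nitrogen whose other neighbours are: double-bonded nitrogen. Going by the values given here, no measured pair isolates this exchange, so this assay offers no direct precedent for it.

The expectation rests on compound 3 and its limit of > 200 uM. No shift beyond the scatter is expected in either direction, and the estimated change is a step that the limit leaves unreadable from compound 3 to compound 4. For compound 4 the estimated value is 240 uM, with an expected range from 120 uM to 450 uM.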

Compound 4, concentration for 50% inhibition: 50 uM
Compound 4: middle estimate off by 4.8-fold (0.68 log units), on the high side; the measured number lies below the stated range.
By their numbers in this assay, from the lowest: compounds 4 and 1 (each within the scatter of the next); then compound 2. At a limit, above all of these: compound 3.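

In this assay, carbamoyl in place of the sulfur-bearing group on the amine nitrogen gives an at least 4.0-fold lower number from compound 3 to compound 4 (0.60 log units; beyond the scatter). Going by these compounds alone, no earlier pair differed in only one place, so this is the first sign that the number responds to a change at this position. Compound 3 holds only a limit of the assay, > 200 uM, and the step is therefore a bound rather than a full size: the limit of > 200 uM in this assay, at which 1 of the 4 values shown sits.

Going by these compounds, whether other groups on this amine nitrogen, such as an acetyl or a methyl group, would give a number near that of compound 4 remains open. Also open, on these data alone, is whether the same carbamoyl exchange would lower the number of compound 2, whose core differs from that of compound 3.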